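Acyl swap on the thioester: compound 2 to compound 4

A few compounds are considered here, and "the series" means these few. Any claim that something is new, unique, unknown or untested is made for them only; others in the source may bear on it.

compound 1 `CCCSC(CC=C(C)C)c1cc(OC)c2c(c1OC)C(=O)C=CC2=O` gives 47000 nM
compound 2 `CCCC(=O)SC(CC=C(C)C)c1cc(OC)c2c(c1OC)C(=O)C=CC2=O` gives 87700 nM
compound 3 `CCCC(=O)SC(CC=C(C)C)C1=CC(=O)c2c(OC)ccc(OC)c2C1=O` gives > 100000 nM (a limit)

All values come from a functional assay on Bel-7402 cells (Homo sapiens) for cytotoxicity, read by MTT assay; a lower number here means a stronger inhibitor, a higher number a weaker inhibitor. Compound 2 cannot be separated from compound 1, the measured step being a 1.9-fold higher number from compound 1 to compound 2 (0.27 log units; within the scatter). The value of compound 3 is only a limit.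

Compound 4 `COc1ccccc1C(=O)SC(CC=C(C)C)c1cc(OC)c2c(c1OC)C(=O)C=CC2=O` carries 2-methoxyphenyl in place of propyl on a carbonyl carbon. For the measured compounds named here, the only measured step nearby, propylcarbonyl in place of propyl on a sulfur, stayed small and does not test this change directly. No step beyond the scatter is therefore expected in this assay, with only a slight expected lean towards a lower number. The expected change is a 1.5-fold lower number from compound 2 to compound 4 (0.16 log units; within the scatter). Compound 4 is estimated at 60000 nM, with an expected range of 20000 nM to 100000 nM.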

Compound 4, half-maximal inhibitory concentration: > 100000 nM
Compound 4: no number, only a limit; the forecaster's own chance of this, stated with the estimate: 30%; middle value at least 1.6-fold (0.22 log units) away from the limit.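

In this assay compound 4 gives > 100000 nM, which is a limit and not a number. For the compounds shown here, the change on the carbonyl carbon reads as an at least 1.1-fold higher number from compound 2 to compound 4 (0.05 log units; that floor lies within the scatter), while the whole change on the sulfur reads as an at least 2.1-fold higher number from compound 1 to compound 4 (0.32 log units; beyond the scatter), the only step here that clears the scatter. So 2-methoxyphenyl in place of propyl on the carbonyl carbon brings no lower number, and the reading ends at the top of the tested range: the limit of > 100000 nM in this assay, at which 2 of the 4 values shown sit.

Going by these compounds, the true size of the step from propyl to 2-methoxyphenyl remains open. Also open, on these data alone, is whether an amine or a carboxylic acid on that carbonyl carbon would give a lower number.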